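Swapping a Ring for a Short Chain on the Oxygen

The compounds below may be only part of what the source reports. "The series", "measured", "known", "first", "only" and "open" are said of these compounds alone.

Of the compounds shown here, three built on one shared core have been measured in a functional assay (cardiac atrium) for agonist activity, with Cavia porcellus as the target; on this read-out lower numbers stand for an effect already at smaller amounts and higher numbers for an effect only at larger amounts of compound. Compound 1, `CO/C(O)=C1\C(C)=NC(C)=C([N+](=O)[O-])C1c1ccncc1`, gives 48500 nM. Compound 2, `CC1=NC(C)=C([N+](=O)[O-])C(c2ccncc2)/C1=C(\O)OC1CCCC1`, gives 4250 nM. Compound 3, `CCO/C(O)=C1\C(C)=NC(C)=C([N+](=O)[O-])C1c1ccccn1`, gives 22800 nM. Compound 2 thus stands with the lowest number of the three, and its steps to compound 3 and to compound 1 are both beyond the scatter, so it is the most potent of these three in this assay.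

Compound 4, `COCCO/C(O)=C1\C(C)=NC(C)=C([N+](=O)[O-])C1c1ccncc1`, has not yet been measured. It differs from compound 2 in one place: 2-methoxyethyl in place of cyclopentyl on an oxygen on an unsaturated carbon. For the measured compounds named here, only one measured step concerns this same oxygen, the change an 11-fold lower number from compound 1 to compound 2 (1.06 log units; beyond the scatter), in which moving from methyl to cyclopentyl went with a large drop in the number. The 2-methoxyethyl group is neither the small methyl of compound 1 nor the cyclopentyl ring of compound 2, so the reasonable expectation is a number higher than that of compound 2 but not all the way back to compound 1, a step beyond the scatter in the weaker direction. This corresponds to an expected step of a 3.5-fold higher number from compound 2 to compound 4 (0.55 log units; beyond the scatter). Compound 4 is therefore estimated to give about 15000 nM, within a range from 5000 nM to 45000 nM.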

Compound 4, half-maximal effective concentration: 37700 nM
Estimate against measurement, compound 4: 2.5-fold (0.40 log units) below, within the range that was stated.
By their numbers in this assay, from the lowest: compound 2; then compounds 3, 4 and 1 (each within the scatter of the next, the first and the last beyond it).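

In this assay, putting 2-methoxyethyl in place of cyclopentyl on this oxygen gives an 8.9-fold higher number from compound 2 to compound 4 (0.95 log units; beyond the scatter), so the advantage of compound 2 is lost with this open chain. The chain also leaves compound 4 level with the methyl compound, with a 1.3-fold lower number from compound 1 to compound 4 (0.11 log units; within the scatter), which means that extending methyl to 2-methoxyethyl makes no difference that can be read here. A group larger than methyl on this oxygen is therefore not enough in itself: among these three groups only cyclopentyl stands apart, and no measurement at hand accounts for the gap between the ring and the chain.

Cyclopentyl and 2-methoxyethyl differ both in having a ring and in having an oxygen in the group, so the compounds shown leave open which of these two differences matters; a plain pentyl chain and a tetrahydrofuranyl ring on the same oxygen would pull them apart. On these data alone, whether the number would fall further with a larger ring, such as cyclohexyl, also remains open.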